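A Saturated Ring Replaces an Aromatic Ether

The source may report more compounds than this note shows. Statements on the series, on what has been measured and on what is new or still open speak of the compounds shown alone.

Three compounds share one core and differ only in a single group on an aromatic carbon. In an ADME assay on HepG2 cells (Homo sapiens) for cytotoxicity, read by luminescence, CellTiter-Glo and ATP content, with a stated time of 72 h (on this read-out higher numbers stand for an effect only at larger amounts of compound and lower numbers for an effect already at smaller amounts), compound 1 (`c1ccc(CCc2ccc3c(NCCCNCc4ccco4)ccnc3c2)cc1`) gives 16000 nM as its reading, compound 2 (`Fc1ccc(Cc2ccc3c(NCCCNCc4ccco4)ccnc3c2)cc1`) gives 5600 nM and compound 3 (`COc1ccccc1Oc1ccc2c(NCCCNCc3ccco3)ccnc2c1`) gives 6500 nM on the same scale. Compound 3 therefore shares the low end of this small set with compound 2, while compound 1 stands apart.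

Compound 4 (`c1coc(CNCCCNc2ccnc3cc(CC4CCCCC4)ccc23)c1`) alters one group of compound 3, with cyclohexylmethyl in place of 2-methoxyphenoxy on an aromatic carbon. Three measured steps change the group at this same place. Exchanging 4-fluorobenzyl for 2-methoxyphenoxy made no difference beyond the scatter (a 1.2-fold higher number from compound 2 to compound 3 (0.06 log units; within the scatter)). The other two steps are modest (a 2.9-fold lower number from compound 1 to compound 2 (0.46 log units; beyond the scatter)) and (a 2.5-fold lower number from compound 1 to compound 3 (0.39 log units; beyond the scatter)). Going by the values given here, no measured compound carries a non-aromatic ring here, so direct precedent is missing. With changes at this place staying this small, no step beyond the scatter is expected in this assay for this swap. The estimated change for compound 4 is slight (a 1.1-fold higher number from compound 3 to compound 4 (0.03 log units; within the scatter)). For compound 4 the estimated value is 7000 nM with an expected range from 2800 nM to 16000 nM (kept wide because so few compounds inform it).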

Compound 4, half-maximal effective concentration: 1700 nM
Beside the measured number, compound 4's estimate is 4.1-fold (0.61 log units) above it; the whole stated range lies above it.
By their numbers in this assay, from the lowest: compound 4; then compounds 2 and 3 (each within the scatter of the next); then compound 1.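

Going by these compounds alone, compound 4 is the first compound here with a non-aromatic ring at this place, and this change gives a 3.8-fold lower number from compound 3 to compound 4 (0.58 log units; beyond the scatter) in this assay, so the group here does matter beyond the swap between compound 2 and compound 3, whose numbers lie within the scatter of each other. The same picture appears when only the ring on the saturated chain carbon differs, with a 3.3-fold lower number from compound 2 to compound 4 (0.52 log units; beyond the scatter) for cyclohexyl in place of 4-fluorophenyl, while a 9.4-fold lower number from compound 1 to compound 4 (0.97 log units; beyond the scatter) for cyclohexyl in place of benzyl is the largest step in this small set and leaves compound 4 with the lowest number of the four. No outside measurement is available to say what lies behind this shift, so the data record the size of the step and nothing about its cause.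

On these data alone, all of this rests on a single compound with a non-aromatic ring, so it remains open whether the shift belongs to saturated rings in general or to cyclohexylmethyl alone. Also open, as far as these compounds go, is how the number would move with a cyclopentyl ring, a piperidine ring or a carboxylic acid at this place on the shared core.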